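A Second Methoxy on a Tolerated Core

The source may report more compounds than this note shows. Statements on the series, on what has been measured and on what is new or still open speak of the compounds shown alone.

Of the compounds shown here, two on the shared core have so far been tested in an ADME assay on HEK293 cells (Homo sapiens) for cytotoxicity, with a stated time of 6 h (a lower number here means that less compound is tolerated, a higher number that more compound is tolerated), and neither gives an exact number. Compound 1 `CCCCNc1nc(N)nc2cc(OC)ccc12` reads > 18000 nM as a limit of the assay. Compound 2 `CCCCNc1nc(N)nc2ccc(OC)cc12` reads > 18000 nM and that too is only a limit. The whole record is thus the limit of > 18000 nM in this assay, at which 2 of the 2 values shown sit, and it sets no order between the two.

Compound 3 `CCCCNc1nc(N)nc2cc(OC)c(OC)cc12` follows from compound 2 with methoxy in place of hydrogen on an aromatic carbon, ortho to a methoxy group methoxy in place of hydrogen on an aromatic carbon and the rest of the core unchanged. Among the measured compounds shown here, no measured pair shows what such a change does in this assay so the expectation is for no shift beyond the usual scatter. This expectation rests on compound 2 at > 18000 nM as its only anchor. The expected move a step that the limit leaves unreadable from compound 2 to compound 3 is therefore small, and a further limit rather than a number is the likelier report. For compound 3 the estimated value is 20000 nM with 9000 nM to 40000 nM as the expected range.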

Compound 3, half-maximal cytotoxic concentration: > 18000 nM
Compound 3: a limit, no number (the forecaster's own chance of this, stated with the estimate: 70%); the middle value lies beyond the limit too.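

In this assay compound 3 gives > 18000 nM as a limit of the assay and not a number. Among the compounds shown here, no step from compound 1 or compound 2 to compound 3 can be read, and all three compounds stand at one limit: the limit of > 18000 nM in this assay, at which 3 of the 3 values shown sit. The compounds shown leave open how far any of them lies beyond that limit.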